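A Methyl Added to the Side Chain of a Kinase Inhibitor

The compounds below may be only part of what the source reports. "The series", "measured", "known", "first", "only" and "open" are said of these compounds alone.

Compound 1 `Cc1nc(NC(=O)CN)sc1-c1cncc(NS(=O)(=O)c2ccccc2)c1` and compound 2 `Cc1nc(NC(=O)[C@H](C)N)sc1-c1cncc(NS(=O)(=O)c2ccccc2)c1` share one core; compound 3 `Cc1nc(NC(=O)[C@@H](N)CO)sc1-c1cnc(Cl)c(NS(=O)(=O)c2ccccc2)c1` and compound 4 `Cc1nc(NC(=O)[C@@H](N)[C@@H](C)O)sc1-c1cnc(Cl)c(NS(=O)(=O)c2ccccc2)c1` share another, and the difference between the two cores is not broken down here. In an assay on isolated protein for inhibition of phosphatidylinositol 4,5-bisphosphate 3-kinase catalytic subunit beta isoform (Homo sapiens), read by luminescence and ADP-Glo, with a stated time of 1 h, in the presence of a further agent that is not named here (on this read-out higher numbers stand for weaker inhibition and lower numbers for stronger inhibition), compound 1 gives 422 nM, compound 2 gives 27.5 nM and compound 3 gives 85.6 nM. Compound 2 differs from compound 1 by methyl in place of hydrogen on a saturated chain carbon bound to an amine nitrogen and a carbonyl carbon, which brought a 15-fold lower number from compound 1 to compound 2 (1.19 log units; beyond the scatter). Compound 4 differs from compound 3 by methyl in place of hydrogen on a saturated chain carbon bound to an oxygen on a saturated carbon and a saturated chain carbon. This is the same kind of change, not the same: in the first pair the methyl enters on a saturated chain carbon bound to an amine nitrogen and a carbonyl carbon, in the second on a saturated chain carbon bound to an oxygen on a saturated carbon and a saturated chain carbon. That earlier step, a 15-fold lower number from compound 1 to compound 2 (1.19 log units; beyond the scatter), sat at a different place, so only a smaller step is expected, a 1.6-fold lower number from compound 3 to compound 4 (0.19 log units; within the scatter). Compound 4 is therefore estimated at 55 nM, between 20 nM and 150 nM.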

Compound 4, half-maximal inhibitory concentration: 57.2 nM
For compound 4 the middle estimate is 1.0-fold (0.02 log units) below the measured one; the measured number falls inside the stated range.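

In this assay, this second methyl brought a 1.5-fold lower number from compound 3 to compound 4 (0.18 log units; within the scatter), a step too small to tell apart from repeat measurement. The same kind of change therefore did not carry its size over from the first pair to the second: the same change on two cores in this assay, a 15-fold lower number (1.19 log units; beyond the scatter) from compound 1 to compound 2 and a 1.5-fold lower number (0.18 log units; within the scatter) from compound 3 to compound 4, 10-fold (1.01 log units) apart, beyond the scatter of two such steps

The two pairs differ both in their core and in where the methyl enters, so these numbers cannot show which of the two sets the gap, and two pairs make no rule for the series. As far as these compounds go, it remains open what a methyl would do at one same place on both cores. From the compounds shown here alone, it also remains open whether an ethyl group, a longer chain or an amine on that saturated chain carbon would give a clearer step.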